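The source may report more compounds than this note shows. Statements on the series, on what has been measured and on what is new or still open speak of the compounds shown alone.

Measured compounds:
- compound 1, `CCOC(=O)Nc1ccc([Se][Se]c2ccc(NC(=O)OCC)cc2)cc1`, 52200 nM in a functional assay on PC-3 cells (Homo sapiens) for cytotoxicity, read by MTT assay, with a stated time of 72 h; on this read-out lower numbers stand for stronger inhibition of growth and higher numbers for weaker inhibition of growth
- compound 2, `C=CCOC(=O)Nc1ccc([Se]C#N)cc1`, 44700 nM in this assay
- compound 3, `CCCCOC(=O)Nc1ccc([Se][Se]c2ccc(NC(=O)OCCCC)cc2)cc1`, 52500 nM in this assay

Among these three numbers, compound 2 holds the lowest one. Its nearest neighbour is compound 1 and its furthest is compound 3, and both of them sit within the usual scatter of repeated measurements, so the three compounds cannot be separated from one another on this read-out. For the measured compounds named here, no step between any two of the measured compounds is available, since no pair differs in only one place.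

The unmeasured compound 4, `N#C[Se]c1ccc(NC(=O)Oc2ccccc2)cc1`, differs from compound 2 in one place: phenyl in place of allyl on an oxygen next to a carbonyl group. The carbamate and the selenocyanate-bearing ring of compound 2 are kept. Nothing in the measured set speaks to what a phenyl in place of an allyl at this position does, and the three measured numbers lie so close together that no direction can be read from them. In this assay the step of a 1.1-fold lower number from compound 2 to compound 4 (0.03 log units; within the scatter) is therefore expected to be none beyond the scatter. Compound 4 is estimated at 42000 nM, with a range from 15000 nM to 110000 nM.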

Compound 4, concentration for total growth inhibition: 37500 nM
The estimate for compound 4 lay 1.1-fold (0.05 log units) above the measured number; the measured number falls inside the stated range.
By their numbers in this assay, from the lowest: compounds 4, 2, 1 and 3 (each within the scatter of the next).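

For the compounds shown here, the step of a 1.2-fold lower number from compound 2 to compound 4 (0.08 log units; within the scatter) in this assay is the first one that can be read at this position, on an oxygen next to a carbonyl group, and it lies within the scatter, so compound 2 and compound 4 cannot be told apart on this read-out. Within this one pair, allyl with its double bond and phenyl with its six-membered aromatic ring of carbon only give numbers that cannot be separated, so neither the double bond nor the ring makes a difference here beyond the scatter. No evidence is at hand that would account for this result.

The compounds shown leave open whether any group on this oxygen would move the number beyond the scatter, for instance a phenyl carrying an amine or a carboxylic acid, or a chain ending in an amine. They also leave open what the selenocyanate itself contributes, as no pair shown sets it against another group, such as a thiocyanate, with the carbamate kept the same.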